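Amide series: ring amine replaces dipropylamino on the pyridine-type core

A few compounds are considered here, and "the series" means these few. Any claim that something is new, unique, unknown or untested is made for them only; others in the source may bear on it.

Of the compounds shown here, three of the shared core have been measured in a functional assay on CHO-K1 cells for antagonist activity at transient receptor potential cation channel subfamily V member 1 (Homo sapiens), read by FLIPR; on this read-out higher numbers stand for weaker inhibition and lower numbers for stronger inhibition. Compound 2 `CCCN(CCC)c1nc(C(F)(F)F)ccc1CNC(=O)C(C)c1ccc(NS(C)(=O)=O)c(F)c1` gives 0.2 nM, the lowest of the three numbers. Compound 3 `CC1CCCN1c1nc(C(F)(F)F)ccc1CNC(=O)[C@@H](C)c1ccc(NS(C)(=O)=O)c(F)c1` gives 0.3 nM, which lies within the scatter of compound 2, so no order between these two is claimed. Compound 1 `CC(C(=O)NCc1ccc(C(F)(F)F)nc1NCC1CCN(C(=O)OC(C)(C)C)CC1)c1ccc(NS(C)(=O)=O)c(F)c1` gives 19.3 nM, a gap from compound 2 that lies beyond the scatter; compound 1 is the only one of the three carrying a hydrogen-bond donor at that position of the core.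

Compound 4 `CC(C(=O)NCc1ccc(C(F)(F)F)nc1N1CCN(C)CC1)c1ccc(NS(C)(=O)=O)c(F)c1` is not yet measured. It differs from compound 2 in one place: 4-methylpiperazin-1-yl in place of dipropylamino on an aromatic carbon. The new group sits on an aromatic carbon next to the ring nitrogen, meta to the trifluoromethyl group, and like compound 3 it closes the amine into a ring while keeping the same count of heavy atoms as in compound 2.

Because compound 2 gives 0.2 nM and compound 3 gives 0.3 nM, both far below compound 1, a number in the low range is expected for compound 4, with a modest move toward weaker inhibition allowed for the second ring nitrogen. The expected step is a 7.5-fold higher number from compound 2 to compound 4 (0.88 log units; beyond the scatter). Compound 4 is estimated at 1.5 nM, in the range 0.3 nM to 8 nM.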

Compound 4, inhibition constant: 146 nM
Compound 4: the middle estimate sits 97-fold (1.99 log units) below what was measured; the measured number lies above the stated range.
By their numbers in this assay, from the lowest: compounds 2 and 3 (each within the scatter of the next); then compound 1; then compound 4.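

In this assay, 4-methylpiperazin-1-yl in place of dipropylamino on this aromatic carbon gives a 730-fold higher number from compound 2 to compound 4 (2.86 log units; beyond the scatter), so a large loss at this position can occur between two groups with the same count of heavy atoms. Among the earlier compounds, only compound 1 stood far from the low numbers, and it carries a hydrogen-bond donor at this place, whereas neither group in this step has a hydrogen-bond donor or a net charge. On paper the step trades a carbon for a second nitrogen, adds a hydrogen-bond acceptor and replaces the open propyl chains with a six-membered non-aromatic ring, and no measurement at hand bears on which of these differences accounts for the step.

The compounds shown leave open whether the second ring nitrogen, its methyl group or the ring as a whole goes with the higher number. A 4-methylpiperidin-1-yl group, with carbon at the second ring position, and a morpholin-4-yl group, with oxygen there, would each help separate these possibilities when compared with compound 4 at the same aromatic carbon.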